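The compounds below may be only part of what the source reports. "The series", "measured", "known", "first", "only" and "open" are said of these compounds alone.

Working notes on the series. Among the measured compounds shown here, in a physicochemical assay for solubility, measured as kinetic solubility, at pH 6.5 (a higher number here means a more soluble compound, a lower number a less soluble compound), compound 2 (`CNC(=O)c1ccc(-c2ccc3nnc([C@@H](C)c4ccc5ncccc5c4)n3n2)cc1`) gives 11000 nM and holds the higher of the two numbers so far. Compound 1 (`COc1ccc(-c2ccc3nnc([C@@H](C)c4ccc5ncccc5c4)n3n2)cc1C`) gives 1770 nM in the same measurement.

The next compound is compound 3 (`C[C@@H](c1ccc2ncccc2c1)c1nnc2ccc(-c3ccc(N(C)C)nc3)nn12`), which has 6-(dimethylamino)pyridin-3-yl in place of 4-(methylcarbamoyl)phenyl on an aromatic carbon of the shared core. The counted difference reads: 6-(dimethylamino)pyridin-3-yl in place of 4-(methylcarbamoyl)phenyl on an aromatic carbon and this is the whole of the change.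

For the measured compounds named here, only one measured step bears on it. That step is a 6.2-fold higher number from compound 1 to compound 2 (0.79 log units; beyond the scatter) and it came with the arrival of 4-(methylcarbamoyl)phenyl in place of 4-methoxy-3-methylphenyl on an aromatic carbon. Going by the values given here, compound 3 gives up that same group, and no measured compound carries 6-(dimethylamino)pyridin-3-yl, so this single step is the only guide to size.

A modest step to a lower number in this assay is therefore expected, no larger than the measured one. The estimated change is a 2.8-fold lower number from compound 2 to compound 3 (0.44 log units; beyond the scatter) on this reasoning. Compound 3 is expected at 4000 nM with an estimated range from 1200 nM to 12000 nM in this measurement.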

Compound 3, solubility: 16200 nM
Compound 3: the middle estimate sits 4.1-fold (0.61 log units) below what was measured, and the stated range ends below it.
By their numbers in this assay, from the lowest: compound 1; then compounds 2 and 3 (each within the scatter of the next).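

On this aromatic carbon, the exchange of 4-(methylcarbamoyl)phenyl for 6-(dimethylamino)pyridin-3-yl in this assay gives a 1.5-fold higher number from compound 2 to compound 3 (0.17 log units; within the scatter) and so leaves the two compounds indistinguishable, even though the entering group has 0 hydrogen-bond donors where the leaving group has 1. The number seen with compound 2 is therefore not unique to 4-(methylcarbamoyl)phenyl, and a hydrogen-bond donor in this group is not needed to reach that level in this pair. Compound 1 remains apart from both compounds, with a 9.2-fold higher number from compound 1 to compound 3 (0.96 log units; beyond the scatter) as a second step from 4-methoxy-3-methylphenyl, and no measured support for any cause of these differences is available here.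

Still open, going by these compounds, is whether the gap from compound 1 tracks the methoxy and methyl groups of 4-methoxy-3-methylphenyl or the substituents carried by compounds 2 and 3, which an unsubstituted phenyl at this position would help to separate. A morpholine in place of the dimethylamino group, or a carboxylic acid in place of the methylcarbamoyl group, would test whether the level held by compounds 2 and 3 extends beyond these two groups.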